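Methyl for Fluoro on the Fused Ring of Compound 1

The source may hold more compounds than are shown below. What is called first, only, known or untested is meant among the compounds shown, and "the series" means these compounds.

Going by the values given here, compound 1 `CS(=O)(=O)c1ccc(Nc2nccc(Nc3nc4ccc(F)cc4s3)n2)cc1` is the one member of the measured trio that gives a number in a functional assay on PC-3 cells (Homo sapiens) for antiproliferative activity, read by MTT assay, with a stated time of 48 h; a higher number here means a weaker inhibitor, a lower number a stronger inhibitor: compound 1 gives 1940 nM. Compound 2 `Cc1cnc(Nc2ccc(S(C)(=O)=O)cc2)nc1Nc1nc2ccc(F)cc2s1` sits at a limit of the assay, > 50000 nM. Compound 3 `CS(=O)(=O)c1ccc(Nc2ncc(F)c(Nc3nc4ccc(F)cc4s3)n2)cc1` also sits at a limit, > 50000 nM. Both of these limits are the limit of > 50000 nM in this assay, at which 2 of the 3 values shown sit. The two readable steps are large: an at least 25-fold higher number from compound 1 to compound 2 (1.41 log units; beyond the scatter), and an at least 25-fold higher number from compound 1 to compound 3 (1.41 log units; beyond the scatter). Between the two limits, a step that the two limits leave unreadable from compound 2 to compound 3.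

Compound 4 `Cc1ccc2nc(Nc3ccnc(Nc4ccc(S(C)(=O)=O)cc4)n3)sc2c1` differs from compound 1 by methyl in place of fluoro on an aromatic carbon, the change sitting on an aromatic carbon of the six-membered carbon-only ring within the fused two-ring system, meta to a fused ring and para to a fused ring. Neither measured step touches that ring; both concern a substituent on the other aromatic ring of the shared core, and neither therefore speaks directly to this exchange. Among the compounds with values here, with no step at this place and a small, neutral swap of one heavy atom for another, the expected change is modest, and compound 4 is expected to show a 1.5-fold higher number from compound 1 to compound 4 (0.19 log units; within the scatter). Compound 4 is estimated at 3000 nM, within 800 nM to 15000 nM.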

Compound 4, half-maximal inhibitory concentration: > 50000 nM
Compound 4: only a limit was reported (the forecaster's own chance of this, stated with the estimate: 10%); at least 16-fold (1.22 log units) between middle value and limit.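

In this assay, the six-membered carbon-only ring of the fused system proves sensitive: methyl in place of fluoro on this aromatic carbon gives an at least 25-fold higher number from compound 1 to compound 4 (1.41 log units; beyond the scatter). The earlier steps had shown so large a change only on the other aromatic ring of the shared core, so this result adds a second place where a swap of one heavy atom for another matters. Compound 4 reports only a limit, the same one reached by compound 2 and compound 3: the limit of > 50000 nM in this assay, at which 3 of the 4 values shown sit.

How far compound 4 lies past that limit cannot be read, and the compounds at the limit cannot be ordered among themselves. As far as these compounds go, whether hydrogen, chloro, methoxy or an amine on this aromatic carbon would keep a readable number remains open.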